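Solubility of a quinoline-like series: toward a methoxyphenyl analogue

The compounds below may be only part of what the source reports. "The series", "measured", "known", "first", "only" and "open" are said of these compounds alone.

In a physicochemical assay for solubility, with a stated time of 18 h, at pH 7.4 (on this read-out lower numbers stand for lower solubility and higher numbers for higher solubility), two compounds of the shared core have been measured. Compound 1 `COc1cccc(Oc2ccc3c(NCCCNCc4ccco4)ccnc3c2)c1` gives 14500 nM, and compound 2 `Fc1ccc(Cc2ccc3c(NCCCNCc4ccco4)ccnc3c2)cc1` gives 4200 nM. Within the data shown here, the one step between them, a 3.5-fold lower number from compound 1 to compound 2 (0.54 log units; beyond the scatter), is the only guide available. Compound 2 thus stands at the lowest of the two numbers, with compound 1 the nearest neighbour at a higher value.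

Compound 3 `COc1ccc(-c2ccc3c(NCCCNCc4ccco4)ccnc3c2)cc1` has not yet been measured. It differs from compound 2 in one place: 4-methoxyphenyl in place of 4-fluorobenzyl on an aromatic carbon. The change is not a repeat of the measured step, since the 3-methoxyphenoxy group of compound 1 is not the 4-methoxyphenyl group entering here, so the earlier step bears on it only loosely. Both compound 1 and compound 3 carry a methoxy-bearing ring at the same position, and compound 1 lies above compound 2, which argues against a fall. The account therefore expects at most a modest change, a 1.1-fold higher number from compound 2 to compound 3 (0.03 log units; within the scatter), for compound 3 in this assay, and estimates compound 3 at 4500 nM, within a range from 1500 nM to 14000 nM.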

Compound 3, solubility: 32000 nM
Beside the measured number, compound 3's estimate is 7.1-fold (0.85 log units) below it; the whole stated range lies below it.
By their numbers in this assay, from the lowest: compound 2; then compound 1; then compound 3.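

In this assay, compound 3 stands highest of the three, and the swap of 4-fluorobenzyl for 4-methoxyphenyl gives a 7.6-fold higher number from compound 2 to compound 3 (0.88 log units; beyond the scatter), even though the group leaving and the group entering have the same count of heavy atoms and each holds one six-membered aromatic ring of carbon only; at this position, then, heavy-atom count alone does not set the number among these compounds. Carrying a methoxy group does not fix the number either: both compound 1 and compound 3 have one, yet 4-methoxyphenyl in place of 3-methoxyphenoxy gives a 2.2-fold higher number from compound 1 to compound 3 (0.34 log units; beyond the scatter), so the two methoxy-bearing groups are not interchangeable here. Nothing available accounts for the size or direction of either step.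

On these data alone, compound 2 and compound 3 differ in both the fluorine-for-methoxy exchange and the way the ring is attached, so the share of each remains open, and a 4-fluorophenyl or 3-methoxyphenyl group at the same position would be needed to separate them. Also open, as far as these compounds go, is how far the number would move with a group of another kind on this aromatic carbon, such as an amine or a carboxylic acid.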